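Thiazole acetic acids: arrestin efficacy, step to compound 4

The compounds below may be only part of what the source reports. "The series", "measured", "known", "first", "only" and "open" are said of these compounds alone.

Measured compounds:
- compound 1, `O=C(O)Cc1sc(C(c2ccccc2)c2ccccc2)nc1-c1ccccc1`: 80%
- compound 2, `Nc1nc(-c2ccc(Cl)cc2)c(CC(=O)O)s1`: 50%
- compound 3, `O=C(O)Cc1sc(C(c2ccc(F)cc2)c2ccc(F)cc2)nc1-c1ccnc(N2CCCC2)c1`: 80%

All three numbers come from an in vitro functional assay on HEK285-7 cells for antagonist activity at prostaglandin D2 receptor 2 (Homo sapiens), read by BRET and beta-arrestin recruitment; a higher number here means a larger maximal response, a lower number a smaller maximal response. Compound 3 gives 80% in this assay, level with compound 1 at the digits shown, and together these two are the highest of the three. The nearest neighbour in value is compound 1, with no change within the scatter; the furthest is compound 2, whose value lies lower by a margin beyond the scatter.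

The next compound, compound 4, `O=C(O)Cc1sc(C(c2ccc(F)cc2)c2ccc(F)cc2)nc1-c1cc(F)nc(F)c1`, is unmeasured. It differs from compound 3 in one place: 2,6-difluoropyridin-4-yl in place of 2-(pyrrolidin-1-yl)pyridin-4-yl on an aromatic carbon. Going by the values given here, no measured pair shows this change directly, so no step size is known for it. The only other variation at this place in the shared core is compound 2, which also differs elsewhere, so its lower value cannot be tied to this position alone.

The step estimated a number 10 percentage points lower from compound 3 to compound 4 (within the scatter) is expected to be small, downward if anything, and within or just beyond the scatter. For compound 4 the estimated maximal response in this assay is 70%, with a range of 50% to 90%.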

Compound 4, largest response reached (reported as efficacy), in percent of the reference or control that the assay uses: 80%
The estimate for compound 4 lay 10 percentage points below the measured number, within the range that was stated.
By their numbers in this assay, from the lowest: compound 2; then compounds 1, 3 and 4 (each within the scatter of the next).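

In this assay, going by these compounds alone, 2,6-difluoropyridin-4-yl in place of 2-(pyrrolidin-1-yl)pyridin-4-yl gives no change at the digits printed from compound 3 to compound 4 (within the scatter), the only direct reading of a change at this position. The maximal response at this aromatic carbon therefore holds when the five-membered non-aromatic ring leaves and fluorine enters on the pyridine, so this pair shows no dependence of the read-out on that difference. Nothing at hand accounts for this result.

Still open, from the compounds shown here alone, is whether a pyridin-4-yl carrying a primary amine or a methoxy group, or a plain phenyl with the 4-fluorophenyl groups of compound 3 retained, would stay level in this assay. Compound 2 differs from the others in more than one place, and its value cannot yet be assigned to this position.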